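Swapping the amine tail on compound 2

The source may report more compounds than this note shows. Statements on the series, on what has been measured and on what is new or still open speak of the compounds shown alone.

Measured compounds:
compound 1 `COc1ncc(-c2ccc3nccc(-c4ccc(C)cc4)c3c2)cc1NS(=O)(=O)c1ccc(F)cc1F` — 67100 nM
compound 2 `CCN(Cc1ccc(-c2ccnc3ccc(-c4cnc(OC)c(NS(=O)(=O)c5ccc(F)cc5F)c4)cc23)cc1)C1CCCCC1` — 1450 nM

In a functional assay on U-87MG ATCC cells (Homo sapiens) for cytotoxicity, read by MTT assay, with a stated time of 72 h (a lower number here means a stronger inhibitor, a higher number a weaker inhibitor), compound 2 gives 1450 nM, the lowest of the two numbers measured. Its nearest neighbour, compound 1, gives 67100 nM. Among the compounds with values here, the one measured step, a 46-fold lower number from compound 1 to compound 2 (1.67 log units; beyond the scatter), is large and lies beyond the scatter; it shows that attaching an amine to that chain carbon matters greatly.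

Compound 3 `CNCCN(C)Cc1ccc(-c2ccnc3ccc(-c4cnc(OC)c(NS(=O)(=O)c5ccc(F)cc5F)c4)cc23)cc1` differs from compound 2 by methyl(2-(methylamino)ethyl)amino in place of cyclohexyl(ethyl)amino on a saturated chain carbon bound to an aromatic carbon. Within the data shown here, no measured step covers an exchange of one amine for another; the step from compound 1 to compound 2 bears on it only in showing that an amine at this place is worth keeping, and compound 3 keeps one. A shift of this assay from compound 2 to compound 3 is therefore expected to be small, a 1.4-fold higher number from compound 2 to compound 3 (0.14 log units; within the scatter), with no clear direction. Compound 3 is estimated at 2000 nM, between 500 nM and 8000 nM.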

Compound 3, half-maximal inhibitory concentration: 254 nM
Compound 3: the middle estimate sits 7.9-fold (0.90 log units) above what was measured; measured number outside the range, below it.
By their numbers in this assay, from the lowest: compound 3; then compound 2; then compound 1.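

The kind of amine matters at this place, not only its presence: in this assay, exchanging one amine for another on the saturated chain carbon bound to an aromatic carbon still moves the number (a 5.7-fold lower number from compound 2 to compound 3 (0.76 log units; beyond the scatter)). Against the compound with plain hydrogen there, the change is now larger still (a 260-fold lower number from compound 1 to compound 3 (2.42 log units; beyond the scatter)). This exchange removes the six-membered ring and adds a methylamino end together, and no supporting measurement shows why the number falls.

The compounds shown cannot separate the loss of the ring from the gain of the methylamino end. A simple dimethylamino group would test whether the ring's absence is enough, and a longer chain between the two nitrogens would test whether their spacing counts.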